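Swapping a Five-Membered Ring for a Six-Membered One

The compounds below may be only part of what the source reports. "The series", "measured", "known", "first", "only" and "open" are said of these compounds alone.

Three compounds with a shared core were tested in a functional assay on CHO-K1 cells for antagonist activity at adenosine receptor A1 (Homo sapiens), read by a beta-galactosidase reporter and cAMP accumulation, with stated times of 15 min and 6 h; on this read-out higher numbers stand for weaker inhibition and lower numbers for stronger inhibition. Compound 1 `Cc1csc(-c2nc(N)c3cc(C4(c5ccccc5)CC4)sc3n2)n1` gives only a limit, > 610 nM. Compound 3 `N#Cc1cccc(-c2nc(N)c3cc(Cc4ccccc4F)sc3n2)c1` likewise gives only a limit, < 16 nM. Going by the values given here, compound 2 `Cc1nc(-c2nc(N)c3cc(Cc4ccccc4)sc3n2)cs1` is the one compound with a number, 263 nM. The other two values are limits: the limit of < 16 nM in this assay, at which 1 of the 3 values shown sits, and (the limit of > 610 nM in this assay, at which 1 of the 3 values shown sits). Compound 4 `Nc1nc(-c2ncccn2)nc2sc(Cc3ccccc3)cc12` has not yet been measured; it differs from compound 2 by pyrimidin-2-yl in place of 2-methyl-1,3-thiazol-4-yl on an aromatic carbon. Among the compounds with values here, no step between two measured compounds is available, so the size of this change in this assay is open; the expectation is no step beyond the scatter, with a slight drift toward weaker inhibition possible. Compound 4 is therefore estimated at 350 nM, with a range from 70 nM to 1800 nM. That estimate means an expected step of a 1.3-fold higher number from compound 2 to compound 4 (0.12 log units; within the scatter), kept within the scatter.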

Compound 4, inhibition constant: 618 nM
Beside the measured number, compound 4's estimate is 1.8-fold (0.25 log units) below it; the measured number falls inside the stated range.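

Swapping pyrimidin-2-yl for 2-methyl-1,3-thiazol-4-yl on this aromatic carbon gives the first readable step at this position in this assay: a 2.3-fold higher number from compound 2 to compound 4 (0.37 log units; beyond the scatter). The two groups have the same counts of heavy atoms and hydrogen-bond acceptors, yet the number still moves, so those counts alone do not set the value here. Nothing measured here accounts for the step.

From the compounds shown here alone, how a morpholine ring or an open-chain amine would read at this position remains open. Going by these compounds, whether the same swap gives a step of like size on the core of compound 1 also remains open.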